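The compounds below may be only part of what the source reports. "The series", "measured", "known", "first", "only" and "open" are said of these compounds alone.

Of the compounds shown here, three built on one shared core have been tested in a functional assay on KETR3 cells (Homo sapiens) for inhibition, read by MTT assay, with a stated time of 120 h; on this read-out lower numbers stand for stronger inhibition and higher numbers for weaker inhibition. Compound 1 `CC(NC(=O)C#Cc1ccc(NC(=O)Nc2ccc(Cl)c(C(F)(F)F)c2)cc1)c1ccccc1` gives 21400 nM. Compound 3 `CNC(=O)C#Cc1ccc(NC(=O)Nc2ccc(Cl)c(C(F)(F)F)c2)cc1` gives 24700 nM. For compound 2 `CNC(=O)/C=C(\C)c1ccc(NC(=O)Nc2ccc(Cl)c(C(F)(F)F)c2)cc1` only a limit of the assay is recorded, > 50000 nM, which is the limit of > 50000 nM in this assay, at which 1 of the 3 values shown sits.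

Compound 3 and compound 1 differ in one place: 1-phenylethyl in place of methyl on an amide-type nitrogen. That change gave a 1.2-fold lower number from compound 3 to compound 1 (0.06 log units; within the scatter). Compound 3 and compound 2 differ in their cores: 1-methyl-2-(methylcarbamoyl)ethenyl in place of 2-(methylcarbamoyl)ethynyl on an aromatic carbon. Between these two, an at least 2.0-fold lower number from compound 2 to compound 3 (0.30 log units; that floor lies within the scatter).

Compound 4 `C/C(=C\C(=O)NC(C)c1ccccc1)c1ccc(NC(=O)Nc2ccc(Cl)c(C(F)(F)F)c2)cc1` has not yet been measured. It stands to compound 2 as compound 1 stands to compound 3: 1-phenylethyl in place of methyl on an amide-type nitrogen. The place is the same in both pairs, so this is the same change. Since the earlier instance, a 1.2-fold lower number from compound 3 to compound 1 (0.06 log units; within the scatter), stayed within the scatter, the step from compound 2 to compound 4 is expected to be similar, a step that the limit leaves unreadable from compound 2 to compound 4, in this assay. Compound 4 is therefore estimated at 60000 nM, with a fair chance that the assay again reports only a limit.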

Compound 4, half-maximal inhibitory concentration: > 50000 nM
Compound 4: a limit, no number (the forecaster's own chance of this, stated with the estimate: 65%); the middle value lies beyond the limit too.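

Compound 2 and compound 4 are both recorded only as limits and not as numbers, so the step between them cannot be read: the limit of > 50000 nM in this assay, at which 2 of the 4 values shown sit.

The compounds shown leave open whether 1-phenylethyl in place of methyl on an amide-type nitrogen changes anything on the core of compound 2, and how far past the limit compound 2 and compound 4 lie.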